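Nitrophenylhydrazone on the bis-benzyloxy core

The compounds below may be only part of what the source reports. "The series", "measured", "known", "first", "only" and "open" are said of these compounds alone.

For the measured compounds named here, compound 3 `O=c1cc(/C=N\c2ccc(O)cc2)c2c(OCc3ccccc3)cc(OCc3ccccc3)cc2o1` gives 3570 nM in a functional assay, read by spectrophotometry, with a stated time of 3 min (on this read-out higher numbers stand for weaker inhibition and lower numbers for stronger inhibition), the lowest number of the three measured so far; the nearest is compound 2 `O=c1cc(/C=N\Nc2ccc([N+](=O)[O-])cc2)c2ccc(OCc3ccccc3)cc2o1` at 9510 nM, and the furthest is compound 1 `N/N=C\c1cc(=O)oc2cc(OCc3ccccc3)cc(OCc3ccccc3)c12` at 363000 nM, both gaps beyond the scatter. Going by the values given here, the only step measured within one place is a 100-fold lower number from compound 1 to compound 3 (2.01 log units; beyond the scatter), which shows that replacing the bare amino on the double-bonded nitrogen with an aryl substituent moves the number a long way down.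

Compound 4 `O=c1cc(/C=N\Nc2ccc([N+](=O)[O-])cc2)c2c(OCc3ccccc3)cc(OCc3ccccc3)cc2o1` is not yet measured. Its difference from compound 3 is (4-nitrophenyl)amino in place of 4-hydroxyphenyl on a double-bonded nitrogen. Among the compounds with values here, no measured step covers this exact exchange. Within the data shown here, compound 2 already carries the (4-nitrophenyl)amino group on a core with a single benzyloxy, and compound 4 places the same group on the core of compound 3; the values of compound 2 and compound 3 differ by a gap beyond the scatter, and no step between them is on record, so the core difference cannot be separated from the substituent difference.

Compound 4 is therefore expected to land near the number of compound 2, at an estimated 6000 nM with a range of 1500 nM to 25000 nM, meaning an expected step of a 1.7-fold higher number from compound 3 to compound 4 (0.23 log units; within the scatter), within the scatter.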

Compound 4, half-maximal inhibitory concentration: 15500 nM
For compound 4 the middle estimate is 2.6-fold (0.41 log units) below the measured one, and the stated range covers the measured number.
By their numbers in this assay, from the lowest: compound 3; then compounds 2 and 4 (each within the scatter of the next); then compound 1.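

On the core of compound 3, the place on the double-bonded nitrogen separates two aryl-bearing groups: in this assay there is a 4.3-fold higher number from compound 3 to compound 4 (0.64 log units; beyond the scatter) when (4-nitrophenyl)amino enters in place of 4-hydroxyphenyl, so the identity of the group matters here and not only the presence of an aromatic ring. The large fall from the bare amino is also not confined to 4-hydroxyphenyl, since a 23-fold lower number from compound 1 to compound 4 (1.37 log units; beyond the scatter) appears when 4-nitrophenyl stands in place of hydrogen on the amine nitrogen, alongside the earlier 100-fold lower number from compound 1 to compound 3 (2.01 log units; beyond the scatter) on the same core. For the compounds shown here, the first comparison of the two cores gives a 1.6-fold higher number from compound 2 to compound 4 (0.21 log units; within the scatter) for benzyloxy in place of hydrogen on an aromatic carbon, so with (4-nitrophenyl)amino in place this added benzyloxy has no effect that can be distinguished from the scatter.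

As far as these compounds go, whether that holds with 4-hydroxyphenyl, and how an amine or a carboxylic acid in place of the nitro group would read, stays open. No measurement on hand gives a reason for any of these steps.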